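The compounds below may be only part of what the source reports. "The series", "measured", "known", "first", "only" and "open" are said of these compounds alone.

Of the compounds shown here, three of one series have been tested and a fourth awaits its result. Compound 1 `O=C(c1nc2cc(Cl)ccc2s1)N1CCN(c2ccccc2)CC1`, compound 2 `O=C(c1nc2cc(Cl)ccc2s1)N1CCN(c2cnccn2)CC1` and compound 3 `O=C(c1nc2ccccc2s1)N1CCN(c2ccccc2)CC1` were examined in an ADME assay on RAW264.7 cells (Mus musculus) for cytotoxicity, read by MTT assay, with a stated time of 72 h, tested at 50 ug/mL; on this read-out lower numbers stand for less inhibition and higher numbers for more inhibition at the one concentration tested (going by the name of the read-out). In this assay compound 1 gives 41.2%, compound 2 gives 54.9% and compound 3 gives 67.2%. Compound 3 therefore stands highest of the three, and its gap to each of the other two lies beyond the usual scatter.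

Two single changes connect the measured compounds. From compound 1 to compound 2 the change is pyrazin-2-yl in place of phenyl on an amine nitrogen in a ring, and this assay shows a number 13.7 percentage points higher from compound 1 to compound 2 (beyond the scatter). The two cores differ as described by hydrogen in place of chloro on an aromatic carbon, and this assay shows a number 26 percentage points higher from compound 1 to compound 3 (beyond the scatter).

Compound 4 `O=C(c1nc2ccccc2s1)N1CCN(c2cnccn2)CC1` is the compound that has not yet been measured. It differs from compound 3 by pyrazin-2-yl in place of phenyl on an amine nitrogen in a ring. Among the compounds with values here, this is the same change as the one from compound 1 to compound 2, and the place where it is made is described in identical words in both cases, so it counts as the same change on the other core.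

The expectation for compound 4 in this assay rests on compound 3 with 67.2% and on the earlier step of a number 13.7 percentage points higher from compound 1 to compound 2 (beyond the scatter). Compound 4 is expected to show a step of about a number 11.8 percentage points higher from compound 3 to compound 4 (beyond the scatter), in the same direction and of a similar size. Compound 4 is therefore estimated at 79%, with a likely range from 63% to 92%.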

Compound 4, a percentage reported as inhibition, at one concentration (the size of the read-out at that concentration, not a potency): 65.3%
Compound 4: middle estimate off by 13.7 percentage points, on the high side, and the stated range covers the measured number.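

In this assay the exchange of phenyl for pyrazin-2-yl on an amine nitrogen in a ring, which raised the number on the core of compound 1, gives a number 1.9 percentage points lower from compound 3 to compound 4 (within the scatter), so on the core of compound 3 it leaves no readable change and the two steps do not agree: the same change on two cores in this assay, a number 13.7 percentage points higher (beyond the scatter) from compound 1 to compound 2 and a number 1.9 percentage points lower (within the scatter) from compound 3 to compound 4, 15.6 percentage points apart, beyond the scatter of two such steps. Seen from the other side, hydrogen in place of chloro on an aromatic carbon gives a number 10.4 percentage points higher from compound 2 to compound 4 (beyond the scatter), in the same direction as before but a smaller step: the same change on two cores in this assay, a number 26 percentage points higher (beyond the scatter) from compound 1 to compound 3 and a number 10.4 percentage points higher (beyond the scatter) from compound 2 to compound 4, 15.6 percentage points apart, beyond the scatter of two such steps. Across these four compounds the size of each change therefore depends on the other change, but the data do not show why, and with one pair on each core they give no rule for any further core.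

The compounds shown leave open whether other groups on that amine nitrogen, such as pyridin-2-yl, pyrimidin-2-yl or an acetyl group, or fluoro or methoxy in place of chloro on that aromatic carbon, would behave alike on the two cores. As far as these compounds go, each number also comes from a single concentration, so how the four compounds compare across a range of concentrations remains open.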